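This account rests on a few compounds, and the source may have more. Where it says the series, first, only, none or still open, it means among the compounds named here.

Measured so far:
compound 1 `N/C(=N/NC(CC(=O)c1ccc(-n2ccnc2)cc1)c1ccccc1Cl)c1ccccn1` — in an ADME assay on Vero cells (Chlorocebus sabaeus) for cytotoxicity, read by MTT assay, with a stated time of 72 h (on this read-out higher numbers stand for lower toxicity in this test and lower numbers for higher toxicity in this test), compound 1 gives 53200 nM
compound 2 `N/C(=N/NC(CC(=O)c1ccc(-n2ccnc2)cc1)c1cccc([N+](=O)[O-])c1)c1ccccn1` — in this assay compound 2 gives 28700 nM

Compound 2 stands at the lowest of the two numbers, though its nearest neighbour, compound 1, differs from it by a step recorded as a 1.9-fold lower number from compound 1 to compound 2 (0.27 log units; within the scatter). Compound 3 `N/C(=N/NC(CC(=O)c1ccc(-n2ccnc2)cc1)c1ccccc1)c1ccccn1` differs from compound 2 by hydrogen in place of nitro on an aromatic carbon. For the measured compounds named here, the only step that bears on this change is the one from compound 1 to compound 2, where one substituted phenyl replaced another and the number moved within the scatter. On that basis no step beyond the scatter is expected for compound 3, and its estimate is a 1.4-fold higher number from compound 2 to compound 3 (0.14 log units; within the scatter), with a value of 40000 nM between 15000 nM and 100000 nM.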

Compound 3, half-maximal cytotoxic concentration: 63500 nM
Estimate against measurement, compound 3: 1.6-fold (0.20 log units) below; measured number inside the range.
By their numbers in this assay, from the lowest: compounds 2, 1 and 3 (each within the scatter of the next, the first and the last beyond it).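

In this assay, for the compounds shown here, the phenyl ring of compound 3 gives the first step beyond the scatter at this position (a 2.2-fold higher number from compound 2 to compound 3 (0.34 log units; beyond the scatter)), a modest one, with hydrogen in place of nitro. Hydrogen in place of chloro gives a step within the scatter (a 1.2-fold higher number from compound 1 to compound 3 (0.08 log units; within the scatter)), so only the nitro change can be told from the scatter here. Nothing at hand accounts for the nitro step. Still open, as far as these compounds go, is how an amine or a carboxylic acid on this ring would read, and whether chloro in the place of the nitro would read like nitro or like hydrogen.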